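Hydroxy for Butyl on the Aryl Ring of Compound 1

The source may report more compounds than this note shows. Statements on the series, on what has been measured and on what is new or still open speak of the compounds shown alone.

Compound 1, `CCCCc1ccc([C@H]2C[C@@H](Nc3nc4cc[nH]c4c(=O)n3C)CN(C)C2)cc1`: 183 nM
Compound 2, `CN1C[C@H](Nc2nc3cc[nH]c3c(=O)n2C)C[C@H](c2ccccc2)C1`: 152 nM
Compound 3, `CN1C[C@H](Nc2nc3cc[nH]c3c(=O)n2C)C[C@H](c2ccc(Cl)c(C(F)(F)F)c2)C1`: 138 nM

Of the compounds shown here, three sharing one core have been measured in an assay on isolated protein for binding affinity to histone acetyltransferase KAT2B (Homo sapiens), read by isothermal titration calorimetry; on this read-out lower numbers stand for tighter binding and higher numbers for weaker binding. Compound 1 carries a butyl on its aromatic ring and gives 183 nM, the highest of the three numbers; its nearest neighbour is compound 2 and its furthest is compound 3, yet both differences lie within the scatter, so the three cannot be put in order. For the measured compounds named here, the only measured step that differs in one place is a 1.2-fold lower number from compound 1 to compound 2 (0.08 log units; within the scatter), hydrogen in place of butyl on an aromatic carbon.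

Compound 4, `CN1C[C@H](Nc2nc3cc[nH]c3c(=O)n2C)C[C@H](c2ccc(O)cc2)C1`, has not yet been measured. It differs from compound 1 by hydroxy in place of butyl on an aromatic carbon. The step from compound 1 to compound 2 bears most directly on this change, since it too takes the butyl away, and it stayed within the scatter. Compound 3, with a different substitution on the same ring, also sits within the scatter of compound 1. No measured compound carries a hydroxy on this ring, so the data give no reason to expect a step beyond the scatter in this assay. For compound 4 the expected value is 160 nM, between 70 nM and 400 nM, which means an expected step of a 1.1-fold lower number from compound 1 to compound 4 (0.06 log units; within the scatter).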

Compound 4, dissociation constant: 120 nM
The estimate for compound 4 lay 1.3-fold (0.12 log units) above the measured number; the range from low to high includes it.
By their numbers in this assay, from the lowest: compounds 4, 3, 2 and 1 (each within the scatter of the next).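

In this assay, putting hydroxy in place of butyl on this aromatic carbon, para to a large group, leaves the number within the scatter (a 1.5-fold lower number from compound 1 to compound 4 (0.18 log units; within the scatter)), and hydroxy in place of hydrogen does the same (a 1.3-fold lower number from compound 2 to compound 4 (0.10 log units; within the scatter)). The earlier butyl-to-hydrogen step showed only that a chain could be removed here without a readable change; these two steps extend that to a group that brings a hydrogen-bond donor and a hydrogen-bond acceptor, which butyl and hydrogen lack. Butyl, hydrogen and hydroxy at this place therefore cannot be told apart on this read-out, and nothing available accounts for that insensitivity.

From the compounds shown here alone, it remains open whether any group at this place can move the number beyond the scatter, for example an amine, a carboxylic acid or a longer chain. A methoxy group at the same carbon would also test whether the hydroxy hydrogen makes any difference, which the three compounds compared here cannot say.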